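Series notes: N-substituent change on the bromo compound

The source may report more compounds than this note shows. Statements on the series, on what has been measured and on what is new or still open speak of the compounds shown alone.

Measured compounds:
- compound 1 `CN1CCCN(CCn2ccc3ccc(Br)cc32)CC1`: 31 nM
- compound 2 `CN1CCCN(CCn2ccc3ccc(OCc4ccccc4)cc32)CC1`: 182 nM
- compound 3 `CN1CCCN(CCn2ccc3ccc(-c4ccsc4)cc32)CC1`: 109 nM

In an assay on HEK293 cells for binding affinity to 5-hydroxytryptamine receptor 7 (Homo sapiens), read by radioligand binding (a higher number here means a weaker inhibitor, a lower number a stronger inhibitor), compound 1 gives the lowest number of the three. The two measured steps both change the aromatic substituent: a 5.9-fold higher number from compound 1 to compound 2 (0.77 log units; beyond the scatter) and a 3.5-fold higher number from compound 1 to compound 3 (0.55 log units; beyond the scatter). Between the other pair, a 1.7-fold lower number from compound 2 to compound 3 (0.22 log units; within the scatter).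

Compound 4 `CC(C)CN1CCCN(CCn2ccc3ccc(Br)cc32)CC1` keeps the bromo substituent of compound 1 and differs only at the ring amine: isopropyl in place of hydrogen on a saturated chain carbon bound to an amine nitrogen in a ring. Among the compounds with values here, none of the measured steps bears on this place; all three measured compounds carry the same methyl on that nitrogen, so nothing here tells how the numbers respond to a larger group there. The expectation therefore rests on the unchanged aromatic part, which gave compound 1 its 31 nM, and on a cautious allowance for the added isopropyl. Compound 4 is estimated at 70 nM, with a range of 20 nM to 250 nM, which would mean an expected step of a 2.3-fold higher number from compound 1 to compound 4 (0.35 log units; beyond the scatter).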

Compound 4, inhibition constant: 37 nM
Compound 4: the middle estimate sits 1.9-fold (0.28 log units) above what was measured; the range from low to high includes it.
By their numbers in this assay, from the lowest: compounds 1 and 4 (each within the scatter of the next); then compounds 3 and 2 (each within the scatter of the next).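

In this assay, the change from methyl to isobutyl on the ring amine gives a 1.2-fold higher number from compound 1 to compound 4 (0.08 log units; within the scatter) and nothing more, so at least on the bromo compound this place accepts the larger chain with no change beyond the scatter. Within the data shown here, the earlier compounds all carried methyl there and showed only that the number responds to the aromatic substituent, so this is the first reading of the ring amine, and it stands apart from the steps away from bromo, both of which lay beyond the scatter. Nothing available explains why the added isopropyl leaves the number in place.

On these data alone, whether the same holds with benzyloxy or thiophen-3-yl on the aromatic carbon remains open. Also open, as far as these compounds go, is how a longer chain, a benzyl group or a carboxylic acid on that ring amine would read.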